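The source may hold more compounds than are shown below. What is called first, only, known or untested is meant among the compounds shown, and "the series" means these compounds.

Measured so far in a functional assay on IMR-32 cells (Homo sapiens) for antiproliferative activity, read by MTT assay; a lower number here means a stronger inhibitor, a higher number a weaker inhibitor
compound 1 `CC(=O)c1ccc(-n2cc(COc3ccc(/C=C/C(=O)c4cc5c(cc4O)OC(C)(C)CC5)cc3)nn2)cc1`: "not active" (no number reported)
compound 2 `COc1ccc(-n2cc(COc3ccc(/C=C/C(=O)c4ccc5c(c4O)CCC(C)(C)O5)cc3)nn2)c([N+](=O)[O-])c1`: 132000 nM
compound 3 `CC1(C)CCc2cc(C(=O)/C=C/c3ccc(OCc4cn(Cc5ccc([N+](=O)[O-])cc5)nn4)cc3)c(O)cc2O1`: 108000 nM

Only two of these compounds carry a number. Compound 2 gives 132000 nM and compound 3 gives 108000 nM, and the two values lie within the usual scatter of each other. Compound 1 has no number to compare, being reported as "not active" (no number reported).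

The next compound to be tested is compound 4 `CCCCCCCCn1cc(COc2ccc(/C=C/C(=O)c3ccc4c(c3O)CCC(C)(C)O4)cc2)nn1`. It has octyl in place of 4-methoxy-2-nitrophenyl on an aromatic nitrogen of the five-membered aromatic ring with 3 nitrogen (octyl in place of 4-methoxy-2-nitrophenyl on an aromatic nitrogen).

Within the data shown here, no two measured compounds differ in only one place, so the data give no direct size for a change of this kind. The expectation is therefore loose. Compound 3 , which has another group on this nitrogen, gives 108000 nM, close to compound 2 , so a large gain in this assay is not expected. Compound 1 , at "not active" (no number reported), shows that a compound of this kind can also give no number at all. A small move toward a lower number is expected, as the estimated step of a 2.2-fold lower number from compound 2 to compound 4 (0.34 log units; beyond the scatter). For compound 4 the expected value is 60000 nM, with an estimated range from 15000 nM to 180000 nM.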

Compound 4, half-maximal inhibitory concentration: "not active" (no number reported)
Nothing numeric was reported for compound 4, so the estimate cannot be set against anything.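

Compound 4 is reported in this assay as "not active" (no number reported), so no step can be read between it and compound 2, which gives 132000 nM. Nothing shown here explains this result. The compounds shown leave open how far octyl in place of 4-methoxy-2-nitrophenyl on this nitrogen shifts the number on its own.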